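This account rests on a few compounds, and the source may have more. Where it says the series, first, only, none or still open, it means among the compounds named here.

In a functional assay on U-87MG ATCC cells (Homo sapiens) for antiproliferative activity (a higher number here means a weaker inhibitor, a lower number a stronger inhibitor), compound 1 (`Cc1c2c(n3c1CCCNC[C@H](C)Nc1cc-3ccc1C(N)=O)CC(C)(C)CC2=O`) gives 366 nM, compound 2 (`Cc1c2c(n3c1CCCN[C@@H](C)[C@H](C)Nc1cc-3ccc1C(N)=O)CC(C)(C)CC2=O`) gives 61 nM and compound 3 (`Cc1c2c(n3c1CCNC[C@@H](C)[C@H](C)Nc1cc-3ccc1C(N)=O)CC(C)(C)CC2=O`) gives 40 nM. Compound 3 therefore stands within the scatter of compound 2 and well clear of compound 1. Compound 4 (`Cc1c2c(n3c1CCN(C)C[C@@H](C)[C@H](C)Nc1cc-3ccc1C(N)=O)CC(C)(C)CC2=O`) differs from compound 3 by one change, methyl in place of hydrogen on an amine nitrogen in a ring. For the measured compounds named here, only one measured step involves a single added methyl, a 6.0-fold lower number from compound 1 to compound 2 (0.78 log units; beyond the scatter). That methyl, however, replaces hydrogen on a saturated ring carbon, so this modest step shows that one methyl can move this assay but gives no direction for the nitrogen. Going by the values given here, no measured pair carries a change on that nitrogen. The expected result is therefore a small shift, perhaps slightly upward, and the estimated step is a 1.6-fold higher number from compound 3 to compound 4 (0.21 log units; within the scatter). Given this thin evidence, the range stays wide on both sides. For compound 4 the estimated value is 65 nM, with an expected range from 22 nM to 200 nM.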

Compound 4, half-maximal inhibitory concentration: 49 nM
Compound 4: middle estimate off by 1.3-fold (0.12 log units), on the high side; the range from low to high includes it.
By their numbers in this assay, from the lowest: compounds 3, 4 and 2 (each within the scatter of the next); then compound 1.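

In this assay, methyl in place of hydrogen on an amine nitrogen in a ring gives a 1.2-fold higher number from compound 3 to compound 4 (0.09 log units; within the scatter), so the added methyl leaves the number within the scatter and the hydrogen on this nitrogen is not required for activity in this range. This differs from a 6.0-fold lower number from compound 1 to compound 2 (0.78 log units; beyond the scatter), where a methyl on a saturated ring carbon moves the number beyond the scatter, so across these two steps a single added methyl does not have the same effect at both places. Nothing available explains why the step at the nitrogen is so small.

As far as these compounds go, whether an ethyl, a longer chain or an acetyl on this nitrogen would leave the number similarly unchanged remains open. It is also open whether the methyl would have so small an effect on the other macrocycles shown, such as compound 1.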